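The source may hold more compounds than are shown below. What is called first, only, known or untested is meant among the compounds shown, and "the series" means these compounds.

Measured so far in a functional assay on 786-0 cells (Homo sapiens) for inhibition, read by sulforhodamine B assay, with a stated time of 48 h; a lower number here means that less compound is tolerated, a higher number that more compound is tolerated:
compound 1 `Nc1cc(N)c2nc(-c3ccccc3)c(NCc3ccc(Cl)c(Cl)c3)nc2c1` gives 70800 nM.
compound 2 `COc1ccc(CNc2nc3cc(N)cc(N)c3nc2-c2ccccc2)cc1OC` gives 75900 nM.
compound 3 `Nc1cc(N)c2nc(-c3ccccc3)c(NCc3ccc(F)cc3)nc2c1` reaches only a limit of the assay, < 100000 nM.

Compound 3 thus stands without a number of its own; the limit of < 100000 nM in this assay, at which 1 of the 3 values shown sits, marks where it sits. Compound 4 `COc1ccc(CNc2nc3cc(N)cc(N)c3nc2-c2ccccc2)cc1` differs from compound 3 by methoxy in place of fluoro on an aromatic carbon. The steps onto compound 3, a step that the limit leaves unreadable from compound 1 to compound 3 and a step that the limit leaves unreadable from compound 2 to compound 3, give no readable size. Going by the values given here, the one readable step at this position, a 1.1-fold higher number from compound 1 to compound 2 (0.03 log units; within the scatter), exchanged two substituted phenyl groups with no shift beyond the scatter. A step that the limit leaves unreadable from compound 3 to compound 4 within the scatter is therefore expected. Compound 4 is estimated at 75000 nM, with a range from 40000 nM to 100000 nM. That places it close to compound 1 and compound 2.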

Compound 4, concentration lethal to 50% of the cells: < 100000 nM
Compound 4 gave a limit, no number; the forecaster's own chance of this, stated with the estimate: 35%; the middle value lies beyond the limit too.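

Compound 4 gives only a limit, < 100000 nM, so no new step to it from compound 1, compound 2 or compound 3 can be read: the limit of < 100000 nM in this assay, at which 2 of the 4 values shown sit.

Left open is where compound 3 and compound 4 truly stand, relative to each other and to compound 1 and compound 2.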